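The source may hold more compounds than are shown below. What is called first, only, known or untested is meant among the compounds shown, and "the series" means these compounds.

Measured so far:
Compound 1 `[SeH]c1nc(NCc2ccccc2)c2cccnc2n1` — 30500 nM
Compound 2 `CCCCC[Se]c1nc(NCc2ccccc2)c2ccccc2n1` — 34500 nM
Compound 3 `CCCCC[Se]c1nc(NCc2ccc(SC)cc2)c2ccccc2n1` — 35000 nM

All three lie within the scatter of one another in a functional assay on CCRF-CEM cells (Homo sapiens) for cytotoxicity, read by MTT assay, with a stated time of 72 h; a higher number here means a weaker inhibitor of growth, a lower number a stronger inhibitor of growth. Compound 3 gives the highest of the three numbers, nearest to compound 2 and furthest from compound 1, but none of these gaps is beyond the scatter, so no order can be read. Going by the values given here, the one single-point step, a 1.0-fold higher number from compound 2 to compound 3 (0.01 log units; within the scatter), changes nothing beyond the scatter.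

Compound 4 `CSc1ccc(CNc2nc(SC)nc3ccccc23)cc1` differs from compound 3 by a group of 2 heavy atoms (1 carbon, 1 sulfur; no ring) in place of a group of 6 heavy atoms (5 carbon, 1 selenium; no ring), on an aromatic carbon. Among the compounds with values here, no measured step addresses this exchange; the group that leaves is shared by compounds 2 and 3 and is never varied. With the series flat so far, the step of no change at the digits printed from compound 3 to compound 4 (within the scatter) is expected to stay within the scatter. Compound 4 is estimated at 35000 nM, within 14000 nM to 85000 nM.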

Compound 4, concentration for 50% growth inhibition: > 100000 nM
Compound 4 ended at the assay's limit; the forecaster's own chance of this, stated with the estimate: 15%; middle value at least 2.8-fold (0.45 log units) from the limit.
By their numbers in this assay, from the lowest: compounds 1, 2 and 3 (each within the scatter of the next). At a limit, above all of these: compound 4.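

Going by these compounds alone, the exchange of the group of 6 heavy atoms (5 carbon, 1 selenium) for methylsulfanyl, on the aromatic carbon between two ring nitrogen atoms, gives the first step beyond the scatter: an at least 2.8-fold higher number from compound 3 to compound 4 (0.45 log units; beyond the scatter). The earlier single-point step, a 1.0-fold higher number from compound 2 to compound 3 (0.01 log units; within the scatter), showed no such response at its position. Compound 4 stands at a limit, not at a number: the limit of > 100000 nM in this assay, at which 1 of the 4 values shown sits.

Selenium and chain length change together in this one step, so the compounds shown do not separate them. A pentylsulfanyl or a methylselanyl group at this position would address that.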